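A Methyl on the Amide Chain of Compound 3

The source may hold more compounds than are shown below. What is called first, only, known or untested is meant among the compounds shown, and "the series" means these compounds.

The compounds here share one core and are compared in a physicochemical assay for solubility, read by HPLC, in phosphate buffer, measured as thermodynamic solubility, with a stated time of 24 h, at pH 6.8; a higher number here means a more soluble compound, a lower number a less soluble compound. Within the data shown here, compound 3 `CCNC(=O)c1cc(F)c(-c2cc3nnn(C4CCN(C(=O)OC(C)C)CC4)c3cn2)cc1F` gives 5500 nM, the highest of the three numbers measured so far. Compound 2 `CCNC(=O)c1cc(C)c(-c2cc3nnn(C4CCN(c5ncc(CC)cn5)CC4)c3cn2)c(C)c1` gives 1860 nM, and compound 1 `CCNC(=O)c1cc(F)c(-c2cc3nnn(C4CCN(c5ncc(CC)cn5)CC4)c3cn2)cc1F` gives 240 nM. Among the measured compounds shown here, the one measured step between compounds that differ in a single place, a 23-fold higher number from compound 1 to compound 3 (1.36 log units; beyond the scatter), concerns the group on the amine nitrogen in the ring, an isopropoxycarbonyl in place of a 5-ethylpyrimidin-2-yl.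

Compound 4 `CC(C)NC(=O)c1cc(F)c(-c2cc3nnn(C4CCN(C(=O)OC(C)C)CC4)c3cn2)cc1F` differs from compound 3 at another place: methyl in place of hydrogen on a saturated chain carbon bound to an amide-type nitrogen and a saturated chain carbon, so that ethylcarbamoyl becomes isopropylcarbamoyl. For the measured compounds named here, no measured step touches this carbamoyl chain; the only measured step, that from compound 1 to compound 3, bears on the other end of the molecule and says nothing about the amide. Going by the values given here, with no step that bears on it, the change is expected to give no step beyond the scatter in this assay, and the expected step of a 1.4-fold lower number from compound 3 to compound 4 (0.14 log units; within the scatter) is accordingly small. Compound 4 is estimated at 4000 nM, with a range from 1500 nM to 11000 nM.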

Compound 4, solubility: 840 nM
Estimate against measurement, compound 4: 4.8-fold (0.68 log units) above, and the stated range ends above it.
By their numbers in this assay, from the lowest: compound 1; then compound 4; then compound 2; then compound 3.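

The carbamoyl chain proved not to be a silent part of the molecule in this assay: the earlier compounds had shown a change only at the group on the amine nitrogen in the ring, whereas ethylcarbamoyl to isopropylcarbamoyl, with that isopropoxycarbonyl group held constant, gives a 6.5-fold lower number from compound 3 to compound 4 (0.82 log units; beyond the scatter). The entering methyl brings only one heavy atom, one carbon, with no ring, no hydrogen-bond donor or acceptor and no net charge, so a change of this size on the chain is the new finding at this position. No measurement among those available accounts for the step, and its cause stays unknown.

The compounds shown leave open whether the step follows the branching on this chain carbon or the added carbon itself, a question that an unbranched propyl chain or a cyclopropyl group in place of the isopropyl would bear on. They also leave open whether the same change would give a step of like direction and size with the 5-ethylpyrimidin-2-yl group on the amine nitrogen, as in compound 1.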